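The source may report more compounds than this note shows. Statements on the series, on what has been measured and on what is new or still open speak of the compounds shown alone.

Working notes on the series in an assay on isolated protein for displacement of a labelled ligand from metabotropic glutamate receptor 5 (Homo sapiens), with a stated time of 60 min, tested at 1 uM; on this read-out lower numbers stand for less inhibition and higher numbers for more inhibition at the one concentration tested (going by the name of the read-out).

Compound 3 `CC1CCN(c2c(S(=O)(=O)c3ccccc3)cnc3ccc(F)cc23)CC1` stands lowest of the three measured compounds: in this assay compound 3 gives 40%. Compound 1 `CC1CCN(c2c(S(=O)(=O)c3ccc(Cl)c(Cl)c3)cnc3ccc(F)cc23)CC1` gives 91% in this assay, and compound 2 `CC1CCN(c2c(S(=O)(=O)c3cccc(Cl)c3)cnc3ccc(F)cc23)CC1` gives 92%. The step of a number 1 percentage points higher from compound 1 to compound 2 (within the scatter) brought a hydrogen in place of chloro on an aromatic carbon. The step of a number 51 percentage points lower from compound 1 to compound 3 (beyond the scatter) put phenyl in place of 3,4-dichlorophenyl on the sulfonyl sulfur, and the step of a number 52 percentage points lower from compound 2 to compound 3 (beyond the scatter) again put hydrogen in place of chloro on an aromatic carbon.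

Compound 4 `CC1CCN(c2c(S(=O)(=O)c3cccc(C#N)c3)cnc3ccc(F)cc23)CC1` differs from compound 3 in one place: cyano in place of hydrogen on an aromatic carbon. The change sits on the aromatic carbon meta to a large group, the same place emptied in the step from compound 2 to compound 3. Going by the values given here, that step was large, so a substituent here is expected to raise the read-out, though cyano is not chloro and no cyano analogue has yet been measured. A rise of a number 32 percentage points higher from compound 3 to compound 4 (beyond the scatter) is estimated for compound 4, that is an expected value of 72%, with a range from 42% to 93%.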

Compound 4, a percentage reported as inhibition, at one concentration (the size of the read-out at that concentration, not a potency): 93%
Beside the measured number, compound 4's estimate is 21 percentage points below it; low and high end bracket the measured number.
By their numbers in this assay, from the lowest: compound 3; then compounds 1, 2 and 4 (each within the scatter of the next).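

In the series, this assay shows through the step of a number 53 percentage points higher from compound 3 to compound 4 (beyond the scatter) that the rise at this aromatic carbon is not confined to chloro: cyano, a group with a triple bond, also gives it. The exchange of groups at this place leaves the read-out within the scatter in the step of a number 1 percentage points higher from compound 2 to compound 4 (within the scatter), and the change to 3-cyanophenyl does the same in the step of a number 2 percentage points higher from compound 1 to compound 4 (within the scatter), so these three compounds cannot be ranked here. No measurement available bears on the cause of the rise.

On these data alone, whether a methoxy group, an amine or a carboxylic acid at this place would also give a rise stays open. Any difference among compound 1, compound 2 and compound 4 also stays open, as each has a value at a single concentration only.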